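The source may hold more compounds than are shown below. What is called first, only, known or untested is meant among the compounds shown, and "the series" means these compounds.

Compound 1: `COc1cc(-c2cc(/C=C/C(=O)c3ccc(N)cc3)[nH]n2)cc(OC)c1OC`, 2820 nM
Compound 2: `COc1ccc(-c2cc(/C=C/C(=O)c3ccc(OC)c(OC)c3)[nH]n2)cc1`, 3530 nM
Compound 3: `COc1cc(-c2cc(/C=C/C(=O)c3ccc(Cl)c(Cl)c3)[nH]n2)cc(OC)c1OC`, 29300 nM

These three compounds were tested in a functional assay on BT-549 cells (Homo sapiens) for inhibition, read by sulforhodamine B assay, with a stated time of 48 h; on this read-out higher numbers stand for weaker inhibition of growth and lower numbers for stronger inhibition of growth. Among them compound 3 gives the highest number, 29300 nM, while compound 2 with 3530 nM and compound 1 with 2820 nM both sit well below it, each beyond the scatter of the measurement. For the measured compounds named here, the only single-point step that has been measured is a 10-fold higher number from compound 1 to compound 3 (1.02 log units; beyond the scatter), a large move toward weaker inhibition of growth when the aminophenyl group on the carbonyl carbon is exchanged for the dichlorinated ring.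

Compound 4, `COc1ccc(C(=O)/C=C/c2cc(-c3cc(OC)c(OC)c(OC)c3)n[nH]2)cc1`, is not yet measured. It differs from compound 3 by 4-methoxyphenyl in place of 3,4-dichlorophenyl on a carbonyl carbon. The measured step from compound 1 to compound 3 bears directly on this change, since it also concerns the aryl group attached to the carbonyl carbon, and it shows that moving away from the dichlorinated ring toward a ring bearing a heteroatom substituent was accompanied by a much lower number. Compound 2, which carries a methoxylated ring on its carbonyl carbon, also sits far below compound 3. A step back toward the range of compounds 1 and 2 is therefore expected, and compound 4 is estimated at 3500 nM, within 1500 nM to 9000 nM, corresponding to an expected step of an 8.4-fold lower number from compound 3 to compound 4 (0.92 log units; beyond the scatter).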

Compound 4, concentration for total growth inhibition: 3860 nM
Beside the measured number, compound 4's estimate is 1.1-fold (0.04 log units) below it; low and high end bracket the measured number.
By their numbers in this assay, from the lowest: compounds 1, 2 and 4 (each within the scatter of the next); then compound 3.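

In this assay the exchange of 3,4-dichlorophenyl for 4-methoxyphenyl on a carbonyl carbon gives a 7.6-fold lower number from compound 3 to compound 4 (0.88 log units; beyond the scatter) and thereby shows that the step away from the dichlorinated ring does not depend on the 4-aminophenyl group of compound 1, since a second ring on the same carbon also lands far below compound 3. Methoxy in place of amino on an aromatic carbon gives a 1.4-fold higher number from compound 1 to compound 4 (0.14 log units; within the scatter) and so leaves these two substituents indistinguishable on this read-out, even though the amino group of compound 1 and the methoxy group of compound 4 are different groups. Nothing measured here speaks to why the dichlorinated ring stands apart from the other two rings.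

The compounds shown do not tell whether both chlorines are needed for the higher number, since a 4-chlorophenyl or a 3-chlorophenyl group on the carbonyl carbon is absent from this set. As far as these compounds go, it also stays open whether other groups on the same ring, such as a hydroxyl, a carboxylic acid or a dimethylamino group, would fall with compound 3 or with compound 1 and compound 4.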